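A methoxy step carried from one pair to another

The compounds below may be only part of what the source reports. "The series", "measured", "known", "first", "only" and "open" are said of these compounds alone.

Three compounds sharing one core were measured in an assay on HEK293 cells for positive allosteric modulation of metabotropic glutamate receptor 2 (Rattus norvegicus), read by thallium flux, with a stated time of 2.5 min; on this read-out lower numbers stand for smaller maximal responses and higher numbers for larger maximal responses. Compound 1 `Cc1c(OCCCCOc2cccc(C(=O)O)c2)ccc(C(=O)CC2CCCC2)c1O` gives 80.6%. Compound 2 `COc1ccc(C(=O)O)cc1OCCCCOc1ccc(C(=O)CC2CCCC2)c(O)c1C` gives 91.8%. Compound 3 `Cc1c(OCCCCOc2cccc(C(=O)O)c2)ccc(C(=O)CC(C)C)c1O` gives 84.5%.

Two single changes connect them. Compound 2 differs from compound 1 by methoxy in place of hydrogen on an aromatic carbon, and this brought a number 11.2 percentage points higher from compound 1 to compound 2 (beyond the scatter). Compound 3 differs from compound 1 by isopropyl in place of cyclopentyl on a saturated chain carbon bound to a carbonyl carbon, and this brought a number 3.9 percentage points higher from compound 1 to compound 3 (within the scatter). Among the three, compound 3 and compound 1 cannot be separated, and compound 3 and compound 2 cannot be separated either.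

Compound 4 `COc1ccc(C(=O)O)cc1OCCCCOc1ccc(C(=O)CC(C)C)c(O)c1C` has not yet been measured. It differs from compound 3 by methoxy in place of hydrogen on an aromatic carbon. This is the same change that turns compound 1 into compound 2, with the same surroundings around the place where it is made; it occurs twice among the four compounds. The two cores on which the change is made differ by isopropyl in place of cyclopentyl on a saturated chain carbon bound to a carbonyl carbon.

For compound 4 in this assay a step of about a number 9.5 percentage points higher from compound 3 to compound 4 (within the scatter) is expected, resting on the step of a number 11.2 percentage points higher from compound 1 to compound 2 (beyond the scatter) seen for the same change on the other core. Compound 4 is therefore estimated to reach 94%, with a range from 85% to 103%. For the measured compounds named here, the range is wide because the only precedent for the step is a number 11.2 percentage points higher from compound 1 to compound 2 (beyond the scatter), a single pair.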

Compound 4, largest response reached (reported as percent of maximum), in percent of the reference or control that the assay uses: 89.7%
Estimate against measurement, compound 4: 4.3 percentage points above; measured number inside the range.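

In this assay the methoxy change on the core of compound 3 gave a number 5.2 percentage points higher from compound 3 to compound 4 (within the scatter), and the two steps for this change cannot be told apart: the same change on two cores in this assay, a number 11.2 percentage points higher (beyond the scatter) from compound 1 to compound 2 and a number 5.2 percentage points higher (within the scatter) from compound 3 to compound 4, 6 percentage points apart, within the scatter of two such steps. The isopropyl change, made on the methoxy-bearing core, gave a number 2.1 percentage points lower from compound 2 to compound 4 (within the scatter), and it too carries across the two cores without a measurable difference: the same change on two cores in this assay, a number 3.9 percentage points higher (within the scatter) from compound 1 to compound 3 and a number 2.1 percentage points lower (within the scatter) from compound 2 to compound 4, 6 percentage points apart, within the scatter of two such steps. This does not show that the methoxy change raises the maximal response on every core: its step lies beyond the scatter only on the core of compound 1 and within it on the core of compound 3, and two cores say nothing about any other core in the series.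

The compounds shown leave open whether another group on the same aromatic carbon, such as ethoxy or chlorine, would behave as methoxy does on these two cores. They also leave open what a longer linking chain, or an amide in place of the carboxylic acid, would do to the maximal response, and whether the two changes would still carry across on such compounds.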